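From tert-butyl to benzyl on the hydroxy chain

The source may report more compounds than this note shows. Statements on the series, on what has been measured and on what is new or still open speak of the compounds shown alone.

In an ADME assay on liver for metabolic stability, with Liver microsome (Homo sapiens) as the target, read by LC-MS, using microsomes (on this read-out lower numbers stand for slow clearance and higher numbers for fast clearance), compound 1 `O=C(NCc1cc(Cl)ccc1-n1cnnn1)[C@@H]1CC=NN1C(=O)[C@H](O)c1ccccc1F` gives 16 mL.min-1.g-1 and compound 3 `O=C([C@H](O)c1ccccc1)N1CC[C@@H]2C[C@@]21C(=O)NCc1cc(Cl)ccc1-n1cnnn1` gives 43 mL.min-1.g-1 as numbers. Compound 2 `CC(C)(C)[C@@H](O)C(=O)N1C[C@@H]2C[C@@H]2[C@H]1C(=O)NCc1cc(Cl)ccc1-n1cnnn1` stands only at a limit (< 15 mL.min-1.g-1) and has no number. Compound 4 `O=C(NCc1cc(Cl)ccc1-n1cnnn1)[C@@H]1[C@H]2C[C@H]2CN1C(=O)[C@H](O)Cc1ccccc1` carries benzyl in place of tert-butyl on a saturated chain carbon bound to a carbonyl carbon and an oxygen on a saturated carbon. For the measured compounds named here, no measured pair shows this change alone. Compound 1 (16 mL.min-1.g-1) and compound 3 (43 mL.min-1.g-1) both lack tert-butyl, so a moderate rise is expected. In this assay the estimated move is upward (an at least 2.0-fold higher number from compound 2 to compound 4 (0.30 log units; that floor lies within the scatter)) with wide uncertainty. For compound 4 the expected value is 30 mL.min-1.g-1 within an estimated range from 14 mL.min-1.g-1 to 70 mL.min-1.g-1 for this read-out.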

Compound 4, intrinsic clearance in microsomes: 96 mL.min-1.g-1
For compound 4 the middle estimate is 3.2-fold (0.51 log units) below the measured one; the measured number lies above the stated range.
By their numbers in this assay, from the lowest: compound 1; then compound 3; then compound 4. At a limit, below all of these: compound 2.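

In this assay, benzyl in place of tert-butyl on a saturated chain carbon bound to a carbonyl carbon and an oxygen on a saturated carbon brings an at least 6.4-fold higher number from compound 2 to compound 4 (0.80 log units; beyond the scatter). For the compounds shown here, this single change shows that the read-out responds to the group at this position, which the earlier compounds, differing in more than one place, could not show. The full size of the step stays open, because compound 2 stands only at a limit: the limit of < 15 mL.min-1.g-1 in this assay, at which 1 of the 4 values shown sits.

The compounds shown leave open whether cyclohexylmethyl or a chain carrying an amine would read like benzyl or like tert-butyl here.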